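This account rests on a few compounds, and the source may have more. Where it says the series, first, only, none or still open, it means among the compounds named here.

The series shares one core. Compound 1 `CCCCCCCCCCCCCCCCSCc1cc(CSC[C@H](NC(=O)[C@H](C)NC)C(=O)N2CCC[C@H]2C(=O)NC(c2ccccc2)c2ccccc2)cc(CSC[C@H](NC(=O)[C@H](C)NC)C(=O)N2CCC[C@H]2C(=O)NC(c2ccccc2)c2ccccc2)c1` gives 11300 nM in a functional assay on MDA-MB-231 cells (Homo sapiens) for inhibition, with a stated time of 48 h; on this read-out higher numbers stand for an effect only at larger amounts of compound and lower numbers for an effect already at smaller amounts. Compound 2 `CCCCCCCCCCCCCCCCCCCCCCCC(=O)NCCCC[C@H](NC(=O)[C@H](C)NC)C(=O)N1CCC[C@H]1C(=O)NC(c1ccccc1)c1ccccc1` reports only a limit in this assay, > 100000 nM. Compound 3 `CN[C@@H](C)C(=O)N[C@@H](CS)C(=O)N1CCC[C@H]1C(=O)NC(c1ccccc1)c1ccccc1` likewise reports only a limit in this assay, > 100000 nM. So compound 3 stands at the limit of > 100000 nM in this assay, at which 2 of the 3 values shown sit, and only compound 1 gives an actual number. Compound 4 `CN[C@@H](C)C(=O)N[C@@H](CSSC(C)(C)C)C(=O)N1CCC[C@H]1C(=O)NC(c1ccccc1)c1ccccc1` has not been measured; it differs from compound 3 by (tert-butyl)sulfanyl in place of hydrogen on a sulfur. Going by the values given here, no measured pair covers that change, so the expected step of an at least 1.2-fold lower number from compound 3 to compound 4 (0.09 log units; that floor lies within the scatter) is small, and compound 3 sitting at the limit leaves it uncertain in either direction. Compound 4 is estimated at 80000 nM, within 20000 nM to 200000 nM, most likely again a limit.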

Compound 4, half-maximal effective concentration: 49900 nM
Compound 4: middle estimate off by 1.6-fold (0.20 log units), on the high side; low and high end bracket the measured number.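

On the sulfur of the shared core, whose other neighbour is a saturated chain carbon, (tert-butyl)sulfanyl in place of hydrogen gives an at least 2.0-fold lower number from compound 3 to compound 4 (0.30 log units; that floor lies within the scatter) in this assay. Going by these compounds alone, this is the first change at this position to lead from a limit to an actual number. Going by these compounds, its full size stays unknown, since compound 3 gives only a limit: the limit of > 100000 nM in this assay, at which 2 of the 4 values shown sit.

The compounds shown leave open how methylsulfanyl, phenylsulfanyl or an aminoethylsulfanyl group would read at this sulfur. They also leave open whether a tert-butyl group joined directly to this sulfur would read the same.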